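Distal Ring Swap: Methylpiperazine Replaces Hydroxyethylpiperidine

This account rests on a few compounds, and the source may have more. Where it says the series, first, only, none or still open, it means among the compounds named here.

Compound 1 `Cc1cc(C)c(S(=O)(=O)N2CCC(N3CCC(c4ccccc4)CC3)CC2)c(C)c1`: 865 nM
Compound 2 `CC1CCN(C2CCN(S(=O)(=O)c3cccnc3Cl)CC2)CC1`: > 5000 nM (a limit)
Compound 3 `Cc1cc(C)c(S(=O)(=O)N2CCC(N3CCC(CCO)CC3)CC2)c(C)c1`: 19 nM

In a functional assay on DLD-1 cells (Homo sapiens) for antiproliferative activity, read by CellTiter-Glo, with a stated time of 72 h (on this read-out lower numbers stand for stronger inhibition and higher numbers for weaker inhibition), compound 3 gives 19 nM, the lowest of the two numbers shown. For compound 2 only the limit of > 5000 nM in this assay, at which 1 of the 3 values shown sits, is reported. Among the measured compounds shown here, the one measured step, a 46-fold lower number from compound 1 to compound 3 (1.66 log units; beyond the scatter), shows that a change on that saturated ring carbon can move the number a long way. Compound 4 `Cc1cc(C)c(S(=O)(=O)N2CCC(N3CCN(C)CC3)CC2)c(C)c1` differs from compound 3 by 4-methylpiperazin-1-yl in place of 4-(2-hydroxyethyl)piperidin-1-yl on a saturated ring carbon, which removes the hydrogen-bond donor that the measured step had introduced. For the measured compounds named here, no measured step covers this exact change, so the expectation is uncertain. Compound 4 is estimated at 300 nM, with a range from 50 nM to 3000 nM. This estimate means an expected step of a 16-fold higher number from compound 3 to compound 4 (1.20 log units; beyond the scatter).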

Compound 4, half-maximal inhibitory concentration: 1100 nM
For compound 4 the middle estimate is 3.7-fold (0.56 log units) below the measured one, within the range that was stated.
By their numbers in this assay, from the lowest: compound 3; then compounds 1 and 4 (each within the scatter of the next). At a limit, above all of these: compound 2.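

In this assay the change to 4-methylpiperazin-1-yl gives a 58-fold higher number from compound 3 to compound 4 (1.76 log units; beyond the scatter) and so shows that the low number of compound 3 does not survive a second replacement of 4-(2-hydroxyethyl)piperidin-1-yl on this saturated ring carbon. Compound 4 stands within the scatter of compound 1, even though the two compounds carry different groups at this position. Nothing shown here accounts for this step.

The ring and its substituent change together, so the compounds leave open which of the two matters. A 4-(2-hydroxyethyl)piperazin-1-yl group or a longer hydroxyalkyl chain on the piperidine would help to separate them.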